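The compounds below may be only part of what the source reports. "The series", "measured", "known", "first", "only" and "open" are said of these compounds alone.

In a functional assay on MKN-45 cells (Homo sapiens) for antiproliferative activity (on this read-out lower numbers stand for stronger inhibition and higher numbers for weaker inhibition), compound 1 `COc1ccc(S(=O)(=O)N2CCc3cccc(Nc4ccc(O)cc4)c32)cc1` gives 493 nM; the nearest number recorded belongs to compound 2 `COc1ccc(S(=O)(=O)N2CCc3cccc(Nc4ccc(F)cc4)c32)cc1`, which gives 563 nM, and the step of a 1.1-fold higher number from compound 1 to compound 2 (0.06 log units; within the scatter) sits within the scatter. Compound 3 `COc1ccc(S(=O)(=O)N2CCc3cccc(Nc4ccc(C#N)cc4)c32)cc1` differs from compound 1 by cyano in place of hydroxy on an aromatic carbon. Within the data shown here, the one step that bears on this change is the one to compound 2, where fluoro in place of hydroxy, also with no hydrogen-bond donor entering, moved this assay by no more than the scatter. For compound 3 a step of a 1.1-fold higher number from compound 1 to compound 3 (0.05 log units; within the scatter) is expected, without direction beyond the scatter. Compound 3 is estimated at 550 nM, within 250 nM to 1200 nM.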

Compound 3, half-maximal inhibitory concentration: 92 nM
Estimate against measurement, compound 3: 6.0-fold (0.78 log units) above, and the stated range ends above it.
By their numbers in this assay, from the lowest: compound 3; then compounds 1 and 2 (each within the scatter of the next).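

In this assay, the aromatic carbon para to a large group proves sensitive to what sits on it: cyano in place of hydroxy gives a 5.4-fold lower number from compound 1 to compound 3 (0.73 log units; beyond the scatter), and cyano in place of fluoro gives a 6.1-fold lower number from compound 2 to compound 3 (0.79 log units; beyond the scatter). Both steps lie beyond the scatter, whereas fluoro and hydroxy could not be told apart here, so the loss of the hydrogen-bond donor alone does not track the shift. Nothing measured here says what lies behind the gain with cyano.

The compounds shown leave open whether the gain is particular to the nitrile or extends to other groups on this carbon, such as a primary amide, a carboxylic acid or trifluoromethyl.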